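Fluoro at the para position: what to expect from compound 4

The source may hold more compounds than are shown below. What is called first, only, known or untested is meant among the compounds shown, and "the series" means these compounds.

Measured compounds:
- compound 1, `COc1ccc(-c2nc(-c3ccccc3)c(-c3ccc4c(c3)NC(=O)CO4)[nH]2)cc1`: 19.1%
- compound 2, `Cc1ccccc1-n1cc(-c2ccccc2)c(-c2ccc3c(c2)NC(=O)CO3)n1`: 62.9%
- compound 3, `O=C1COc2ccc(-c3[nH]c(-c4ccccc4)nc3-c3ccccc3)cc2N1`: 47.3%

These three compounds were tested in a functional assay on DLD-1 cells (Homo sapiens) for cytotoxicity, read by colorimetric assay and MTT assay, with a stated time of 3 days, tested at 20 uM; a higher number here means a weaker effect of the compound at the concentration tested, a lower number a stronger effect. Compound 3 sits in the middle of the three numbers: compound 2 lies higher and compound 1 lies lower, both gaps being beyond the scatter.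

Compound 4, `O=C1COc2ccc(-c3[nH]c(-c4ccc(F)cc4)nc3-c3ccccc3)cc2N1`, differs from compound 3 by fluoro in place of hydrogen on an aromatic carbon. Going by the values given here, the only measured step that touches the same place is the one from compound 1 to compound 3, which involves the same aromatic carbon of the same ring: a number 28.2 percentage points higher from compound 1 to compound 3 (beyond the scatter). That step shows that changing this position can move the number by a clear amount. Fluoro is a different group from methoxy, so the direction is uncertain; a small move downward, or none beyond the scatter, seems most likely. Compound 4 is therefore expected at 42%, with a range from 22% to 62%, which corresponds to an expected step of a number 5.3 percentage points lower from compound 3 to compound 4 (within the scatter).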

Compound 4, a percentage reported as activity, at one concentration (the size of the read-out at that concentration, not a potency): 29.5%
For compound 4 the middle estimate is 12.5 percentage points above the measured one, within the range that was stated.
By their numbers in this assay, from the lowest: compound 1; then compound 4; then compound 3; then compound 2.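

Fluoro in place of hydrogen is enough on its own to strengthen the effect in this assay: a number 17.8 percentage points lower from compound 3 to compound 4 (beyond the scatter). The earlier step showed only that methoxy at this aromatic carbon gave a lower number than hydrogen, whereas this result shows that the position also responds to a group of a single heavy atom. Fluoro does not go as far as methoxy, a number 10.4 percentage points higher from compound 1 to compound 4 (beyond the scatter), so the three groups fall in a clear order at this one place, with methoxy lowest, fluoro in the middle and hydrogen highest, and nothing available explains that order.

Going by these compounds, whether an amine, a carboxylic acid or a longer chain such as ethoxy at the same carbon would extend this order remains open. So does the effect of fluoro at other carbons of this ring.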